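Pyridin-2-yl for 4-methylphenyl: antiproliferative working notes

The source may hold more compounds than are shown below. What is called first, only, known or untested is meant among the compounds shown, and "the series" means these compounds.

Measured so far:
- Compound 1 `Cc1ccc(-c2cn(C/C=C3\OC(=O)C(OCc4ccccc4)=C3OCc3ccccc3)nn2)cc1`; in a functional assay on HCT-116 cells (Homo sapiens) for antiproliferative activity, read by MTT assay, with a stated time of 24 h (a higher number here means a weaker inhibitor, a lower number a stronger inhibitor), compound 1 gives > 100000 nM, which is a limit of the assay and not a number.
- Compound 2 `O=C1NC(O)(CCn2cc(C3=CCCCC3)nn2)C(OCc2ccccc2)=C1OCc1ccccc1`; in this assay compound 2 gives > 100000 nM, again a limit and not a number.

Among the compounds with values here, compound 1 therefore stands nowhere that can be ranked: its value is a limit, and the only other value shown is a limit as well, so that both sit at the limit of > 100000 nM in this assay, at which 2 of the 2 values shown sit. Within the data shown here, no step between measured compounds is available, and nothing among the two values suggests that either is the stronger inhibitor.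

The next compound, compound 3 `O=C1O/C(=C\Cn2cc(-c3ccccn3)nn2)C(OCc2ccccc2)=C1OCc1ccccc1`, differs from compound 1 in one place: pyridin-2-yl in place of 4-methylphenyl on an aromatic carbon. The shared core of compound 1 is kept.

With both measured values at the same limit, no shift beyond the scatter is expected for the step that the limit leaves unreadable from compound 1 to compound 3 in this assay. Compound 3 is estimated at 150000 nM, with a range from 30000 nM to 600000 nM, and most likely the assay will again report only a limit.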

Compound 3, half-maximal inhibitory concentration: > 100000 nM
Compound 3: only a limit was reported (the forecaster's own chance of this, stated with the estimate: 75%); the middle value lies beyond the limit too.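

In this assay compound 3 gives > 100000 nM, a limit of the assay and not a number. The step from compound 1 to compound 3 cannot be read, because both values are limits: the limit of > 100000 nM in this assay, at which 3 of the 3 values shown sit.

The compounds shown leave open whether pyridin-2-yl in place of 4-methylphenyl changes antiproliferative activity at all.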